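A few compounds are considered here, and "the series" means these few. Any claim that something is new, unique, unknown or untested is made for them only; others in the source may bear on it.

Working notes on the series. In a functional assay on MDA-MB-231 cells (Homo sapiens) for cytotoxicity, read by resazurin assay, with a stated time of 48 h (a lower number here means a stronger inhibitor, a higher number a weaker inhibitor), compound 1 (`COc1cc(/C=C\c2ccc3[nH]ccc3c2)cc(OC)c1`) gives 250 nM and compound 2 (`COc1cc(/C=C\c2ccc3cc[nH]c3c2)cc(OC)c1`) gives 250 nM. The two stand level, so compound 1 sits at the only level seen so far, with no measured spread to compare it against.

Compound 3 (`COc1cc(/C=C\c2ccc3c(ccn3C)c2)cc(OC)c1`) keeps the core of compound 1 and differs in one place: methyl in place of hydrogen on an aromatic nitrogen. Within the data shown here, no measured compound carries a methyl there, and no measured step shows what this change does. The expectation therefore rests on a single anchor, compound 1 at 250 nM, and stays wide.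

In this assay, no shift beyond the scatter is expected as the most likely outcome, with a slight lean towards a weaker inhibitor and a real chance of a larger loss. The estimated step is a 1.3-fold higher number from compound 1 to compound 3 (0.11 log units; within the scatter). For compound 3 the expected value is 320 nM, with an estimated range of 90 nM to 1100 nM.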

Compound 3, half-maximal inhibitory concentration: 80 nM
Estimate against measurement, compound 3: 4.0-fold (0.60 log units) above, and the stated range ends above it.
By their numbers in this assay, from the lowest: compound 3; then compounds 1 and 2 (each within the scatter of the next).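

In this assay, among these compounds, the hydrogen on the aromatic nitrogen of the five-membered aromatic ring proves not to be needed for activity: methyl in place of hydrogen on an aromatic nitrogen gives a 3.1-fold lower number from compound 1 to compound 3 (0.49 log units; beyond the scatter) and is the first measured step, modest in size but beyond the scatter. This position therefore accepts a small carbon group with a gain rather than a loss, although one step from one pair sets no trend. The data at hand offer no explanation for the gain.

Still open, going by these compounds, is whether the gain stops at methyl or carries over to ethyl, a longer chain, or a chain ending in an amine or a carboxylic acid on the same nitrogen. Among the compounds shown here, also open is whether the same methyl change on the core of compound 2 gives a step of similar size, as the series so far holds only this one example of the change.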